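The compounds below may be only part of what the source reports. "The series", "measured", "known", "first", "only" and "open" are said of these compounds alone.

Measured so far, in this assay:
- compound 1 `COc1ccc(OCCCN(CC(=O)NCc2ccccc2)Cc2ccccc2)cc1OC`: 51.3 nM
- compound 2 `COc1ccc(OCCCN(CC(=O)NCc2ccccc2)Cc2ccc(F)c(F)c2)cc1OC`: 107 nM

Both numbers come from a functional assay on HEK293 cells for antagonist activity at Orexin receptor type 2 (Homo sapiens), read by FLIPR and calcium flux; on this read-out higher numbers stand for weaker inhibition and lower numbers for stronger inhibition. Among the measured compounds shown here, compound 2 stands with the higher of the two numbers; its only neighbour is compound 1, and the one recorded step, a 2.1-fold higher number from compound 1 to compound 2 (0.32 log units; beyond the scatter), is the sole change tried at this position so far.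

Compound 3 `COc1ccc(OCCCN(CC(=O)NCc2ccccc2)Cc2cccs2)cc1OC` has not yet been measured. It differs from compound 2 by thiophen-2-yl in place of 3,4-difluorophenyl on a saturated chain carbon bound to an amine nitrogen. The step from compound 1 to compound 2 bears on this only loosely: it shows that exchanging the aromatic group on that chain carbon moved the number modestly, but compound 3 carries a ring of a different kind, and nothing measured shows how such a ring behaves here. The expectation is therefore a number nearer to that of compound 1 than to compound 2, that is a modest move toward lower numbers, a 1.6-fold lower number from compound 2 to compound 3 (0.22 log units; within the scatter), while a result within the scatter of compound 2 would not be surprising. Compound 3 is estimated at 65 nM, with a likely range from 25 nM to 170 nM.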

Compound 3, half-maximal inhibitory concentration: 132 nM
Estimate against measurement, compound 3: 2.0-fold (0.31 log units) below, within the range that was stated.
By their numbers in this assay, from the lowest: compound 1; then compounds 2 and 3 (each within the scatter of the next).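

In this assay, the step of a 1.2-fold higher number from compound 2 to compound 3 (0.09 log units; within the scatter) shows that at this place, on a saturated chain carbon bound to an amine nitrogen, thiophen-2-yl and 3,4-difluorophenyl cannot be told apart, even though one is a five-membered aromatic ring holding a sulfur atom and the other a six-membered carbon ring bearing two fluorines. The comparison with the plain phenyl of compound 1 is clearer, since the step of a 2.6-fold higher number from compound 1 to compound 3 (0.41 log units; beyond the scatter) lies beyond the scatter, as does a 2.1-fold higher number from compound 1 to compound 2 (0.32 log units; beyond the scatter). Compound 1 therefore remains the strongest inhibitor of the three, and both replacements cost only a modest amount of inhibition, so this position accepts quite different aromatic rings without losing activity altogether.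

Still open, as far as these compounds go, is whether phenyl is truly favoured here or is merely ahead of these two groups, which a pyridin-2-yl ring, a furan-2-yl ring, a 4-fluorophenyl group or a non-aromatic cyclohexyl group at the same place could help to settle. There is also no independent measurement that would explain why these rings give the numbers they do.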